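This account rests on a few compounds, and the source may have more. Where it says the series, first, only, none or still open, it means among the compounds named here.

Going by the values given here, compound 2 `CC(C)(Oc1ccccc1F)C1OCC(C/C=C\CCC(=O)O)C(c2cccnc2)O1` is one of two compounds measured in an assay for inhibition of prostacyclin synthase (Homo sapiens), using microsomes; on this read-out lower numbers stand for stronger inhibition and higher numbers for weaker inhibition. In this assay compound 2 gives < 1000 nM, which is a limit of the assay rather than a number (the limit of < 1000 nM in this assay, at which 1 of the 2 values shown sits). Compound 1 `COc1ccc(OC(C)(C)C2OCC(C/C=C\CCC(=O)O)C(c3cccnc3)O2)cc1` gives > 100000 nM, also a limit (the limit of > 100000 nM in this assay, at which 1 of the 2 values shown sits). Among the compounds with values here, the only measured step, an at least 100-fold lower number from compound 1 to compound 2 (2.00 log units; beyond the scatter), arose from 2-fluorophenyl in place of 4-methoxyphenyl on an oxygen on a saturated carbon. Compound 3 `CC(C)(Oc1ccc(F)cc1[N+](=O)[O-])C1OCC(C/C=C\CCC(=O)O)C(c2cccnc2)O1` is not yet measured; it differs from compound 2 by 4-fluoro-2-nitrophenyl in place of 2-fluorophenyl on an oxygen on a saturated carbon. The measured step shows that the aryl ether on this oxygen moves the read-out strongly, but it does not tell how the 4-fluoro-2-nitrophenyl group will act, and compound 2 itself sits only at a limit. Compound 3 is therefore expected to give about 800 nM in this assay, within 100 nM to 8000 nM, an estimated step that the limit leaves unreadable from compound 2 to compound 3 that could lie in either direction.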

Compound 3, half-maximal inhibitory concentration: 9000 nM
Beside the measured number, compound 3's estimate is 11-fold (1.05 log units) below it; the whole stated range lies below it.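

In this assay, the change to 4-fluoro-2-nitrophenyl gives an at least 9.0-fold higher number from compound 2 to compound 3 (0.95 log units; beyond the scatter), while the same group, set against the 4-methoxyphenyl group, gives an at least 11-fold lower number from compound 1 to compound 3 (1.04 log units; beyond the scatter). The aryl group on this oxygen therefore does not simply switch the read-out between two extremes: compound 3 gives a measured value that lies between the values of the other two, and it is the only one of the three that is not a limit. The value of compound 2 remains a limit of the assay: the limit of < 1000 nM in this assay, at which 1 of the 3 values shown sits.

The compounds shown do not separate the effect of the nitro group from that of the fluorine in 4-fluoro-2-nitrophenyl. They also leave open how an amine or a nitrile in place of that nitro group would read, and how far compound 2 truly lies from compound 3.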